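The compounds below may be only part of what the source reports. "The series", "measured", "known", "first", "only" and "open" are said of these compounds alone.

Measured in an assay on isolated protein for inhibition of serine/threonine-protein kinase 10 (Homo sapiens), read by thermal shift assay, tested at 10 uM; a lower number here means that the compound stabilises the target less, a higher number that the compound stabilises the target more against heat:
compound 1, `CC(C)(C)c1cc(NC(=O)Nc2cc(F)cc(F)c2)n(-c2ccccc2)n1`: 2.5 degrees C
compound 2, `Cn1nc(C(C)(C)C)cc1NC(=O)Nc1cc(F)cc(F)c1`: 1.1 degrees C
compound 3, `CC(C)(C)c1cc(NC(=O)Nc2cc(F)cc(F)c2)n(-c2ccc(F)cc2)n1`: 1.7 degrees C

Compound 3 stands second of the three numbers; the nearer gap is a number 0.60 degrees C higher from compound 2 to compound 3 (within the scatter) and the further one is a number 0.80 degrees C lower from compound 1 to compound 3 (within the scatter); both gaps are within the scatter. Compound 4, `CC(C)(C)c1cc(NC(=O)Nc2cc(F)cc(F)c2)n(-c2ccc(Br)cc2)n1`, differs from compound 3 by bromo in place of fluoro on an aromatic carbon. Among the measured compounds shown here, no measured step exchanges one halogen for another on that ring. For the measured compounds named here, the steps that bear on it are those that alter the substituent on the aromatic nitrogen: a number 0.80 degrees C lower from compound 1 to compound 3 (within the scatter), within the scatter, and a number 1.4 degrees C lower from compound 1 to compound 2 (beyond the scatter), where the phenyl ring itself is lost. Here the ring stays and only the group on it changes, so no step beyond the scatter is expected: a number 0.20 degrees C higher from compound 3 to compound 4 (within the scatter). Compound 4 is estimated at 1.9 degrees C, between 0.8 degrees C and 3 degrees C.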

Compound 4, shift of the target's melting temperature: 0.2 degrees C
Beside the measured number, compound 4's estimate is 1.7 degrees C above it; the whole stated range lies above it.
By their numbers in this assay, from the lowest: compounds 4, 2, 3 and 1 (each within the scatter of the next, the first and the last beyond it).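

In this assay, the group on this aromatic carbon, para to a large group, can move the number beyond the scatter even with the phenyl ring kept: the change from 4-fluorophenyl to 4-bromophenyl gives (a number 1.5 degrees C lower from compound 3 to compound 4 (beyond the scatter)). Bromo in place of hydrogen also gives a step beyond the scatter (a number 2.3 degrees C lower from compound 1 to compound 4 (beyond the scatter)), which fluoro in place of hydrogen did not (a number 0.80 degrees C lower from compound 1 to compound 3 (within the scatter)). Against methyl on the aromatic nitrogen, 4-bromophenyl stays within the scatter (a number 0.90 degrees C lower from compound 2 to compound 4 (within the scatter)).

Nothing available explains the loss seen with bromo. Open, on these data alone, is how chloro, methoxy or an amine on this carbon would read.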